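The source may report more compounds than this note shows. Statements on the series, on what has been measured and on what is new or still open speak of the compounds shown alone.

Measured compounds in an ADME assay on HepG2 cells (Homo sapiens) for cytotoxicity, read by luminescence, CellTiter-Glo and ATP content, with a stated time of 72 h; a higher number here means that more compound is needed for the effect, a lower number that less compound is needed:
- Compound 1 `COc1cccc(CNCCCNc2ccnc3cc(Oc4ccc(F)cc4)ccc23)c1O` gives 11000 nM
- Compound 2 `Fc1ccc(Oc2ccc3c(NCCCNCc4ccco4)ccnc3c2)cc1` gives 16000 nM
- Compound 3 `Cc1cc(C)cc(Cc2ccc3c(NCCCNCc4ccco4)ccnc3c2)c1` gives 6270 nM

Compound 1 stands second highest of the three numbers. Its nearest neighbour is compound 2, with a 1.5-fold higher number from compound 1 to compound 2 (0.16 log units; within the scatter), a step within the scatter that comes from the change of furan-2-yl in place of 2-hydroxy-3-methoxyphenyl on a saturated chain carbon bound to an amine nitrogen. The furthest is compound 3, whose number is lower than that of compound 1 but still within the scatter of it.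

Compound 4 `COc1cccc(CNCCCNc2ccnc3cc(-c4ccccc4)ccc23)c1O` has not been measured. It differs from compound 1 as follows: phenyl in place of 4-fluorophenoxy on an aromatic carbon. Among the measured compounds shown here, the only measured step at the same aromatic carbon is a 2.6-fold lower number from compound 2 to compound 3 (0.41 log units; beyond the scatter), where 3,5-dimethylbenzyl in place of 4-fluorophenoxy gave a modest lowering beyond the scatter. For the measured compounds named here, the group entering in compound 4 is phenyl rather than 3,5-dimethylbenzyl, so that step is only a rough guide; no measured pair shows phenyl in place of 4-fluorophenoxy directly.

On that basis a modest lowering is expected for compound 4, of the order of a 1.6-fold lower number from compound 1 to compound 4 (0.20 log units; within the scatter), though a result within the scatter of compound 1 would not surprise. The estimate for compound 4 in this assay is 7000 nM, with an expected range from 3000 nM to 16000 nM.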

Compound 4, half-maximal effective concentration: 3210 nM
Compound 4: middle estimate off by 2.2-fold (0.34 log units), on the high side, within the range that was stated.
By their numbers in this assay, from the lowest: compounds 4, 3, 1 and 2 (each within the scatter of the next, the first and the last beyond it).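

In this assay, with the 2-hydroxy-3-methoxyphenyl side chain held constant, phenyl in place of 4-fluorophenoxy on this aromatic carbon gives a 3.4-fold lower number from compound 1 to compound 4 (0.53 log units; beyond the scatter), so less compound is needed for the effect with the smaller group of 6 heavy atoms. Alongside a 2.6-fold lower number from compound 2 to compound 3 (0.41 log units; beyond the scatter), this makes two lowerings beyond the scatter on leaving 4-fluorophenoxy, one with each side chain and each with a different entering group, so within these two pairs the lowering is tied to neither one side chain nor one entering group. Nothing measured here accounts for the lowering.

Which part of 4-fluorophenoxy matters stays open: unsubstituted phenoxy and 4-fluorophenyl at this carbon would separate the effect of the oxygen from that of the fluorine. Also open, from the compounds shown here alone, are whether phenyl gives a similar step with the furan-2-yl side chain, and how a carboxylic acid or an amine on the entering phenyl ring would shift the number.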